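Same atoms, new chain: from compound 3 to compound 4

A few compounds are considered here, and "the series" means these few. Any claim that something is new, unique, unknown or untested is made for them only; others in the source may bear on it.

Values in a functional assay for inhibition, with Homo sapiens as the target; a lower number here means that less compound is needed, a higher number that more compound is needed for the effect:
Compound 1 `CCCCC(=O)Nc1ccc(C2=NNC(=O)CC2)cc1`: 2.64 ug/mL
Compound 2 `O=C1CCC(c2ccc(NC(=O)CCCl)cc2)=NN1`: 0.98 ug/mL
Compound 3 `CCC(Cl)C(=O)Nc1ccc(C2=NNC(=O)CC2)cc1`: 1.47 ug/mL

Compound 3 holds the middle of these three numbers, although its distance to each of the other two stays within the scatter. Compound 4 `O=C1CCC(c2ccc(NC(=O)CCCCl)cc2)=NN1` has the same atoms as compound 3, joined differently: a group of 4 heavy atoms (3 carbon, 1 chlorine; no ring) in place of a group of 4 heavy atoms (3 carbon, 1 chlorine; no ring), on a carbonyl carbon. The group that enters is 3-chloropropyl.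

For the measured compounds named here, three measured steps bear on this change. Only one lies beyond the scatter, and it is modest: a 2.7-fold lower number from compound 1 to compound 2 (0.43 log units; beyond the scatter). Another stays within the scatter: a 1.8-fold lower number from compound 1 to compound 3 (0.25 log units; within the scatter). The closest guide swaps one chlorine-bearing group for another, and it also stays within the scatter: a 1.5-fold higher number from compound 2 to compound 3 (0.18 log units; within the scatter). With so few compounds the evidence is thin, but no step beyond the scatter is expected in this assay. The estimated change is small, a 1.1-fold lower number from compound 3 to compound 4 (0.05 log units; within the scatter). For compound 4 the estimated value is 1.3 ug/mL, with an expected range from 0.6 ug/mL to 2.8 ug/mL.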

Compound 4, half-maximal effective concentration: > 46.4 ug/mL
Compound 4: only a limit was reported (the forecaster's own chance of this, stated with the estimate: 3%); middle value at least 35-fold (1.55 log units) from the limit.
By their numbers in this assay, from the lowest: compounds 2, 3 and 1 (each within the scatter of the next, the first and the last beyond it). At a limit, above all of these: compound 4.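

In this assay compound 4 gave no number, only a limit of the assay: the limit of > 46.4 ug/mL in this assay, at which 1 of the 4 values shown sits.

Rearranging the same atoms into 3-chloropropyl on the carbonyl carbon gives an at least 31-fold higher number from compound 3 to compound 4 (1.49 log units; beyond the scatter), so the atoms a group contains do not settle the outcome here; how they are joined matters greatly. The two other comparisons point the same way: chloro in place of methyl on the chain gives an at least 17-fold higher number from compound 1 to compound 4 (1.24 log units; beyond the scatter), and chloromethyl in place of chloro gives an at least 47-fold higher number from compound 2 to compound 4 (1.67 log units; beyond the scatter), both far larger than any step among the three earlier compounds.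

As far as these compounds go, what remains open is whether this sharp rise is tied to chlorine itself or to any group in that place on the chain. 3-Hydroxypropyl or 3-aminopropyl in place of 3-chloropropyl would speak to this, and 4-chlorobutyl would show what a longer chain does.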